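The source may report more compounds than this note shows. Statements on the series, on what has been measured and on what is new or still open speak of the compounds shown alone.

Compound 1 `Cc1ccccc1CNc1nn(-c2ccc(F)cc2F)cc1CNCCN1CCN(C)CC1` was tested in an ADME assay on Huh-7 cells (Homo sapiens) for cytotoxicity; on this read-out lower numbers stand for higher toxicity in this test and higher numbers for lower toxicity in this test. In this assay compound 1 gives > 20000 nM, which is a limit of the assay rather than a number. It stands at the limit of > 20000 nM in this assay, at which 1 of the 3 values shown sits. Two related compounds were also measured: compound 2 `CN1CCN(CCCNCc2cn(-c3ccc(C(F)(F)F)cc3)nc2-c2ccc(C(F)(F)F)cc2)CC1` gives 2000 nM, and compound 3 `CN1CCN(CCNCc2cn(-c3ccc(C(F)(F)F)cc3)nc2-c2ccc(Cl)cc2)CC1` gives 3000 nM, two measurable numbers. Compound 4 `Cc1cccc(-c2nn(-c3ccc(F)cc3F)cc2CNCCN2CCN(C)CC2)c1` has not yet been measured. It differs from compound 1 in one respect: 3-methylphenyl in place of (2-methylbenzyl)amino on an aromatic carbon. Compounds 2 and 3 also carry an aromatic ring on the shared core and give definite numbers in this assay, so a step toward a lower number, beyond the usual scatter, is expected here. The estimate for compound 4 is 8000 nM, within a range of 3000 nM to 20000 nM. This would amount to an expected step of an at least 2.5-fold lower number from compound 1 to compound 4 (0.39 log units; beyond the scatter).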

Compound 4, half-maximal cytotoxic concentration: > 20000 nM
Compound 4: a limit, no number; the forecaster's own chance of this, stated with the estimate: 30%; at least 2.5-fold (0.39 log units) between middle value and limit.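

In this assay, compound 1 and compound 4 both give a limit rather than a number, so no step between them can be read: the limit of > 20000 nM in this assay, at which 2 of the 4 values shown sit.

From the compounds shown here alone, whether 3-methylphenyl in place of (2-methylbenzyl)amino changes the read-out at all remains open.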